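The source may hold more compounds than are shown below. What is called first, only, known or untested is meant among the compounds shown, and "the series" means these compounds.

In a functional assay on A549 cells (Homo sapiens) for antiproliferative activity, read by MTT assay, with a stated time of 72 h (a higher number here means a weaker inhibitor, a lower number a stronger inhibitor), compound 1 (`O=C(N/N=C/c1ccc(F)cc1)Nc1ccc(Oc2ccnc3[nH]ccc23)cc1`) gives 1430 nM and compound 2 (`O=C(N/N=C/c1ccc(O)cc1)Nc1ccc(Oc2ccnc3[nH]ccc23)cc1`) gives 1910 nM on the same shared core. Hydroxy in place of fluoro on an aromatic carbon produces a 1.3-fold higher number from compound 1 to compound 2 (0.13 log units; within the scatter) and so lies within the scatter, which leaves compound 2 level with compound 1 on these numbers. Compound 3 (`CN(C)CCn1cccc1/C=N/NC(=O)Nc1ccc(Oc2ccnc3[nH]ccc23)cc1`) has not yet been measured in this assay. It carries 1-(2-(dimethylamino)ethyl)-1H-pyrrol-2-yl in place of 4-hydroxyphenyl on a carbon with a double bond to nitrogen. Going by the values given here, this exchange replaces a whole group, whereas the one measured step, a 1.3-fold higher number from compound 1 to compound 2 (0.13 log units; within the scatter), changed only a single substituent on an aromatic carbon. That step therefore bears on the new change only weakly. Among the compounds with values here, no measured compound carries the entering group, so the data give no firm direction, and no step clearly beyond the scatter is expected, though with a wide margin either way. The estimated step is a 1.5-fold lower number from compound 2 to compound 3 (0.17 log units; within the scatter) and remains an uncertain expectation. For compound 3 the estimated value is 1300 nM, with an expected range from 350 nM to 4500 nM as the likely span.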

Compound 3, half-maximal inhibitory concentration: "not active" (no number reported)
No number was reported for compound 3; there is nothing to compare the estimate with.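

Going by these compounds alone, in [ this assay ] compound 3 is reported as "not active", without a number, so no step from compound 1 or compound 2 to compound 3 can be read. The compounds shown leave open how far compound 3 actually stands from compound 1 and compound 2. Nothing shown offers an explanation for this result.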